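Chloro for methyl on the sulfonyl phenyl group

The compounds below may be only part of what the source reports. "The series", "measured", "known", "first", "only" and "open" are said of these compounds alone.

Values so far in a functional assay on HepG2 cells (Homo sapiens) for cytotoxicity, read by MTT assay, with a stated time of 24 h (on this read-out higher numbers stand for weaker inhibition and lower numbers for stronger inhibition), are these
Compound 1 `CN1C/C(=C\c2cccnc2)C(=O)/C(=C/c2ccccc2C(F)(F)F)C1` gives 2550 nM
Compound 2 `Cc1ccc(S(=O)(=O)N2C/C(=C\c3cccnc3)C(=O)/C(=C/c3ccccc3C(F)(F)F)C2)cc1` gives 2930 nM

Compound 2 sits level with compound 1 on these two numbers, and neither can be ranked above the other. Compound 3 `O=C1/C(=C/c2cccnc2)CN(S(=O)(=O)c2ccc(Cl)cc2)C/C1=C\c1ccccc1C(F)(F)F` keeps everything in compound 2 except one group, through the change chloro in place of methyl on an aromatic carbon in which chloro takes the place of methyl on an aromatic carbon, turning 4-methylphenyl into 4-chlorophenyl. Within the data shown here, no measured step covers this exchange directly. The nearest evidence is the step that put (4-methylphenyl)sulfonyl in place of methyl on the amine nitrogen in the ring, which gave a 1.1-fold higher number from compound 1 to compound 2 (0.06 log units; within the scatter) and no more. That much larger exchange stayed within the scatter, so no step beyond the scatter is expected in this assay for this smaller one. The estimated move is a 1.0-fold lower number from compound 2 to compound 3 (0.02 log units; within the scatter) and nothing larger. For compound 3 the expected value is 2800 nM with an estimated range from 1400 nM to 5600 nM in this test.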

Compound 3, half-maximal inhibitory concentration: 3620 nM
Beside the measured number, compound 3's estimate is 1.3-fold (0.11 log units) below it, and the stated range covers the measured number.
By their numbers in this assay, from the lowest: compounds 1, 2 and 3 (each within the scatter of the next).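

In this assay, replacing methyl with chloro on the aromatic carbon para to a large group gives a 1.2-fold higher number from compound 2 to compound 3 (0.09 log units; within the scatter), so this place on the sulfonyl phenyl group now has a direct reading, and the two groups cannot be told apart on it. Measured against the methyl on the amine nitrogen, the (4-chlorophenyl)sulfonyl group gives a 1.4-fold higher number from compound 1 to compound 3 (0.15 log units; within the scatter), so a second sulfonyl group joins the first in staying level with that small group. No measurement given here offers an explanation for these results.

Going by these compounds, whether a methoxy, a nitrile or an amine at this place would carry the number beyond the scatter remains open. Also open, on these data alone, is whether a carboxylic acid in place of the trifluoromethyl would do so on the shared core.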